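A few compounds are considered here, and "the series" means these few. Any claim that something is new, unique, unknown or untested is made for them only; others in the source may bear on it.

In an ADME assay on Vero cells (Chlorocebus sabaeus) for cytotoxicity, read by MTT assay, with a stated time of 72 h (on this read-out higher numbers stand for lower toxicity in this test and lower numbers for higher toxicity in this test), compound 1 (`CCOc1ccc(/C=C/C(=O)c2ccc3c(c2O)C=CC(C)(C)O3)cc1`) gives 215000 nM and compound 2 (`CC1(C)C=Cc2c(ccc(C(=O)/C=C/c3ccc(F)cc3)c2O)O1`) gives 158000 nM while compound 3 (`CC1(C)C=Cc2c(ccc(C(=O)/C=C/c3ccc(Cl)cc3Cl)c2O)O1`) gives 131000 nM on the same read-out. Compound 3 thus stands within the scatter of both other compounds, and the three numbers cannot be ranked. Compound 4 (`CC1(C)C=Cc2c(ccc(C(=O)/C=C/c3ccc(C#N)cc3)c2O)O1`) has not yet been measured. It carries 4-cyanophenyl in place of 2,4-dichlorophenyl on a double-bonded chain carbon bound to a double-bonded chain carbon. For the measured compounds named here, two measured steps bear on this change. The closest one, 2,4-dichlorophenyl in place of 4-fluorophenyl at that same place, gave a 1.2-fold lower number from compound 2 to compound 3 (0.08 log units; within the scatter) and fluoro in place of ethoxy on an aromatic carbon gave a 1.4-fold lower number from compound 1 to compound 2 (0.13 log units; within the scatter) so in this assay no step beyond the scatter is expected, in either direction. The step expected is a 1.1-fold higher number from compound 3 to compound 4 (0.06 log units; within the scatter) and it is not expected to leave the scatter. Compound 4 is estimated at 150000 nM with an expected range (80000 nM to 280000 nM).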

Compound 4, half-maximal cytotoxic concentration: 80200 nM
Compound 4: middle estimate off by 1.9-fold (0.27 log units), on the high side, within the range that was stated.
By their numbers in this assay, from the lowest: compounds 4, 3, 2 and 1 (each within the scatter of the next, the first and the last beyond it).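

In this assay, the change to cyano at this place yields the only step among these compounds that leaves the scatter (a 2.7-fold lower number from compound 1 to compound 4 (0.43 log units; beyond the scatter)), where the ethoxy group gives way to cyano. The two closer comparisons, 4-cyanophenyl in place of 2,4-dichlorophenyl (a 1.6-fold lower number from compound 3 to compound 4 (0.21 log units; within the scatter)) and cyano in place of fluoro (a 2.0-fold lower number from compound 2 to compound 4 (0.29 log units; within the scatter)), both stay within the scatter, so only the ethoxy and cyano groups can be told apart in this test, and the others cannot be separated from cyano. Nothing measured here gives a reason for any of these steps.

The compounds shown leave open how an amine or a carboxylic acid on the aromatic ring would read in this assay as a replacement for cyano. They also leave open whether a longer chain in place of ethoxy would give a number that differs from that of the ethoxy group.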